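The source may report more compounds than this note shows. Statements on the series, on what has been measured and on what is new or still open speak of the compounds shown alone.

Compound 1, `Cc1nc(/N=N/N(C)C)c(C(N)=O)[nH]1`, gives 3.06 in a functional assay on L1210 cells (Mus musculus) for antiproliferative activity; on this read-out higher numbers stand for higher potency (the scale is a negative logarithm) and lower numbers for lower potency.
Compound 2, `CN(/N=N/c1nc[nH]c1C(N)=O)c1cccs1`, gives 3.87 in this assay.
Compound 3, `CN(CCO)/N=N/c1ccccc1C(N)=O`, gives 3.07 in this assay.

Among these three numbers, compound 3 stands second highest. Its nearest neighbour is compound 1, whose number lies within the scatter of repeated measurements, so the two cannot be told apart on this read-out. The furthest is compound 2, whose number lies beyond the scatter above compound 3.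

Compound 4, `CN(C)/N=N/c1ccccc1C(N)=O`, has not yet been measured in this assay. It differs from compound 3 in one place: hydrogen in place of hydroxymethyl on a saturated chain carbon bound to an amine nitrogen. Among the measured compounds shown here, no step between two measured compounds shows what this change does on its own, so the direction cannot be read from the data. Removing a small chain group of this kind is expected to move the number little, if at all, beyond the scatter.

Compound 4 is therefore estimated at 3.1, with a range from 2.6 to 3.7. This estimate means a step of a number 0.03 log units higher from compound 3 to compound 4 (within the scatter), expected to stay within the scatter.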

Compound 4, logarithm of the reciprocal of the active concentration, log(1/C): 3.31
Compound 4: middle estimate off by 0.21 log units, on the low side; measured number inside the range.
By their numbers in this assay, from the lowest: compounds 1, 3 and 4 (each within the scatter of the next); then compound 2.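

Cutting the 2-hydroxyethyl on the amine nitrogen back to methyl, which turns the (2-hydroxyethyl)(methyl)amino group into dimethylamino, gives a number 0.24 log units higher from compound 3 to compound 4 (within the scatter) in this assay and leaves the two compounds impossible to tell apart on this read-out. Among the compounds shown here, this single pair is the first direct look at this position, and it shows that, on this core, the number stays within the scatter without the hydroxymethyl and the hydrogen-bond donor and acceptor counted with it. Nothing measured here offers a reason for this result.

One step at one position cannot show how much freedom this chain allows in general. A longer chain, or a chain ending in an amine or a carboxylic acid, could still give a number beyond the scatter, and the compounds shown do not tell either way.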